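This account rests on a few compounds, and the source may have more. Where it says the series, first, only, none or still open, it means among the compounds named here.

Series notes. Compound 1 `CC(C)Cc1cc(CNS(=O)(=O)c2cccc3ccccc23)nn1-c1ccccc1` and compound 2 `CC(C)Cc1cc(CNS(=O)(=O)c2ccc3ccccc3c2)nn1-c1ccccc1` share one core and differ only at the sulfonyl sulfur. In an assay on isolated protein for binding affinity to 5-hydroxytryptamine receptor 6 (Homo sapiens), tested at 10 uM (on this read-out higher numbers stand for more inhibition at the one concentration tested (going by the name of the read-out) and lower numbers for less inhibition), compound 1 gives 77.7% and compound 2 gives 67.8%; the step of a number 9.9 percentage points lower from compound 1 to compound 2 (within the scatter) lies within the scatter. On the two numbers at hand compound 2 stands at the lower end, with compound 1 the nearer value, the gap within the scatter. Compound 3 `Cc1c(Cl)cccc1S(=O)(=O)NCc1cc(CC(C)C)n(-c2ccccc2)n1` is next: 3-chloro-2-methylphenyl in place of naphthalen-2-yl on a sulfonyl sulfur. For the measured compounds named here, the one measured step, a number 9.9 percentage points lower from compound 1 to compound 2 (within the scatter), swaps one two-ring group for another at the same sulfur and so gives only weak guidance for a single ring carrying chlorine and methyl. A step of modest size downward is expected for compound 3, a number 12.8 percentage points lower from compound 2 to compound 3 (beyond the scatter), with wide uncertainty. For compound 3 the estimate in this assay is 55%, range 25% to 80%.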

Compound 3, a percentage reported as inhibition, at one concentration (the size of the read-out at that concentration, not a potency): 72.3%
The estimate for compound 3 lay 17.3 percentage points below the measured number, and the stated range covers the measured number.
By their numbers in this assay, from the lowest: compounds 2, 3 and 1 (each within the scatter of the next).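

At the sulfonyl sulfur, 3-chloro-2-methylphenyl stands in place of the two naphthalenyl groups, giving a number 4.5 percentage points higher from compound 2 to compound 3 (within the scatter) and a number 5.4 percentage points lower from compound 1 to compound 3 (within the scatter) in this assay. With one six-membered aromatic ring carrying chlorine and methyl in place of two fused rings, no step among these three compounds lies beyond the scatter, so the second ring is not required to keep the read-out in this range. No measurement at hand explains this result.

Going by these compounds, the separate contributions of the chlorine and the methyl remain open, as does the outcome for an unsubstituted phenyl or for a ring carrying an amine or a carboxylic acid. On these data alone, each number gives the size of the read-out at one concentration only, so how compound 1, compound 2 and compound 3 compare at any other concentration also remains open.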